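Fluoro in place of dimethylamino: notes on compound 3

A few compounds are considered here, and "the series" means these few. Any claim that something is new, unique, unknown or untested is made for them only; others in the source may bear on it.

Going by the values given here, in a functional assay on NCI-H460 cells (Homo sapiens) for inhibition, with a stated time of 72 h (a lower number here means a stronger inhibitor, a higher number a weaker inhibitor), compound 2 `COc1ccc(S(=O)(=O)N2CCc3cccc(-c4ccc(N(C)C)cc4)c32)cc1` gives 556 nM, the higher of the two numbers so far, and compound 1 `COc1ccc(S(=O)(=O)N2CCc3cccc(-c4ccc(F)nc4)c32)cc1` gives 135 nM. Compound 3 `COc1ccc(S(=O)(=O)N2CCc3cccc(-c4ccc(F)cc4)c32)cc1` carries fluoro in place of dimethylamino on an aromatic carbon, para to a large group: fluoro in place of dimethylamino on an aromatic carbon. Among the compounds with values here, the only measured step bearing on this change is modest and beyond the scatter: a 4.1-fold higher number from compound 1 to compound 2 (0.61 log units; beyond the scatter). Read in reverse, that step suggests a lower number of similar size. The expected change is a 3.5-fold lower number from compound 2 to compound 3 (0.54 log units; beyond the scatter). For compound 3 the estimated value is 160 nM, with an expected range of 60 nM to 400 nM.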

Compound 3, half-maximal inhibitory concentration: 95.5 nM
Beside the measured number, compound 3's estimate is 1.7-fold (0.22 log units) above it; low and high end bracket the measured number.
By their numbers in this assay, from the lowest: compounds 3 and 1 (each within the scatter of the next); then compound 2.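

The direct exchange at this position now has a step of its own in this assay, with only the dimethylamino group leaving and fluoro entering (a 5.8-fold lower number from compound 2 to compound 3 (0.77 log units; beyond the scatter)). With fluoro in place, the 4-fluorophenyl and 6-fluoropyridin-3-yl groups do not separate (a 1.4-fold lower number from compound 1 to compound 3 (0.15 log units; within the scatter)). No evidence on the cause of either step is at hand.

Open, on these data alone, is how a methoxy, a nitrile or a carboxylic acid at this place would compare with fluoro and dimethylamino. Also open, as far as these compounds go, is whether a pyridine carrying dimethylamino would follow the phenyl pair.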